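Two Limits and a Swap of Aromatic Rings

The compounds below may be only part of what the source reports. "The series", "measured", "known", "first", "only" and "open" are said of these compounds alone.

compound 1 `C#Cc1cn([C@@H]2O[C@H](CO)[C@@H](O)[C@H]2O)c2ncnc(SC)c12`: 110 nM
compound 2 `Nc1nc(N)c2c(-c3ccco3)cn([C@@H]3O[C@H](CO)[C@@H](O)[C@H]3O)c2n1`: > 20000 nM (a limit)
compound 3 `COc1nc(N)nc2c1c(-c1ccco1)cn2[C@@H]1O[C@H](CO)[C@@H](O)[C@H]1O`: > 20000 nM (a limit)

In a functional assay on CEM-DNR-bulk cells (Homo sapiens), read by MTT assay, with a stated time of 72 h (a lower number here means a stronger inhibitor, a higher number a weaker inhibitor), compound 3 gives no number, only a limit, and it stands at the limit of > 20000 nM in this assay, at which 2 of the 3 values shown sit. Compound 4 `COc1nc(N)nc2c1c(-c1ccccc1)cn2[C@@H]1O[C@H](CO)[C@@H](O)[C@H]1O` differs from it by one group: phenyl in place of furan-2-yl on an aromatic carbon. Put simply, the furan-2-yl of compound 3 gives way to a phenyl in compound 4. Among the measured compounds shown here, the only measured step, a step that the two limits leave unreadable from compound 2 to compound 3, concerns a different group and has no readable size, so it offers no guide to size or direction here. The data therefore give no reason to expect a clear change. Expected here is a number no higher from compound 3 to compound 4 (the limit leaves the size open), with no clear direction. For compound 4 the estimated value is 20000 nM, with an expected range from 5000 nM to 50000 nM.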

Compound 4, half-maximal inhibitory concentration: > 20000 nM
Compound 4 was reported as a limit; the forecaster's own chance of this, stated with the estimate: 80%; the middle value lies on the limit itself.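

Compound 3 and compound 4 are both reported only as limits, so no new step can be read between them, and most values shown sit at that same limit: the limit of > 20000 nM in this assay, at which 3 of the 4 values shown sit. Going by these compounds, whether phenyl or furan-2-yl gives the stronger inhibitor stays open.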